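Swapping Fluorines for Methyls on the Sulfonamide Aryl

A few compounds are considered here, and "the series" means these few. Any claim that something is new, unique, unknown or untested is made for them only; others in the source may bear on it.

Compound 2 `O=C1NCCN1c1ccc(S(=O)(=O)Nc2ccc(F)c(F)c2)cc1` carries a 3,4-difluorophenyl group on the sulfonamide nitrogen of the shared core. In a functional assay on HT-29 cells (Homo sapiens) for antiproliferative activity, read by sulforhodamine B assay, with a stated time of 48 h (on this read-out higher numbers stand for weaker inhibition and lower numbers for stronger inhibition), compound 2 gives 350 nM, the lowest of the two numbers recorded, although its nearest neighbour sits within the scatter. That neighbour, compound 1 `O=C1NCCN1c1ccc(S(=O)(=O)Nc2ccc(OC(F)F)cc2)cc1`, gives 650 nM in this assay. Compound 3 `CC(C)Cc1ccc(NS(=O)(=O)c2ccc(N3CCNC3=O)cc2)cc1` reaches only a limit of > 1000 nM in this assay, and the account must treat it as a limit rather than a number (the limit of > 1000 nM in this assay, at which 1 of the 3 values shown sits). Among the compounds with values here, the one measured step, an at least 1.5-fold higher number from compound 1 to compound 3 (0.18 log units; that floor lies within the scatter), is the only comparison that involves an alkyl group in place of a fluorinated one, and its floor lies within the scatter.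

Compound 4 `Cc1cc(C)cc(NS(=O)(=O)c2ccc(N3CCNC3=O)cc2)c1` differs from compound 2 by 3,5-dimethylphenyl in place of 3,4-difluorophenyl on a sulfonamide nitrogen. Within the data shown here, no measured step mirrors this exchange on the sulfonamide nitrogen, so the expectation rests on the direction seen when isobutyl replaced difluoromethoxy. A modest rise in the number is therefore expected, plausibly beyond the scatter, and the step of a 2.6-fold higher number from compound 2 to compound 4 (0.41 log units; beyond the scatter) is the estimate for that move. In this assay compound 4 is expected to give about 900 nM, within a range from 300 nM to 3000 nM.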

Compound 4, half-maximal inhibitory concentration: 82 nM
Compound 4: the middle estimate sits 11-fold (1.04 log units) above what was measured; the whole stated range lies above it.
By their numbers in this assay, from the lowest: compound 4; then compounds 2 and 1 (each within the scatter of the next). At a limit, above all of these: compound 3.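

The exchange on the sulfonamide nitrogen lowers the number in this assay (a 4.3-fold lower number from compound 2 to compound 4 (0.63 log units; beyond the scatter)), and this is the only step shown that is printed as beyond the scatter, so this position clearly responds to the choice of aryl group. Within the data shown here, replacing fluorines with alkyl groups on this ring therefore does not raise the number as a rule: compound 4 runs in the opposite direction to the one earlier comparison involving an alkyl group, whose floor lies within the scatter (an at least 1.5-fold higher number from compound 1 to compound 3 (0.18 log units; that floor lies within the scatter)). Nothing among the data shown accounts for the size or the direction of this change.

The exchange alters the substituents on the ring and their placement together, and the compounds shown do not separate these two changes. Also open, as far as these compounds go, is whether a single methyl, a methoxy or an amine on this ring would keep the number near that of compound 4 (82 nM) or lose the gain.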